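The source may report more compounds than this note shows. Statements on the series, on what has been measured and on what is new or still open speak of the compounds shown alone.

Among the measured compounds shown here, compound 2 `COCc1ccc2nccc(SC3(C(=O)O)CCC3)c2c1` is the only compound here with a numerical result: in an assay on HEK293 cells for inhibition of solute carrier family 22 member 12 (Homo sapiens), read by scintillation counting, with a stated time of 12 min (on this read-out higher numbers stand for weaker inhibition and lower numbers for stronger inhibition), compound 2 gives 198 nM. Compound 1 `O=C(O)C1(Sc2ccnc3ccc(O)cc23)CCC1` differs from it in one place, carrying hydroxy where compound 2 carries methoxymethyl. In this assay compound 1 gives > 10000 nM, a limit rather than a number, namely (the limit of > 10000 nM in this assay, at which 1 of the 2 values shown sits). For the measured compounds named here, the single measured step, an at least 50-fold lower number from compound 1 to compound 2 (1.70 log units; beyond the scatter), is therefore the only guide to changes at this position. Compound 3 `O=C(O)C1(Sc2ccnc3ccc(C(F)(F)F)cc23)CCC1` alters the same position again: trifluoromethyl in place of methoxymethyl on an aromatic carbon. Going by the values given here, no measured step involves trifluoromethyl, so the step from compound 1 to compound 2 offers only the hint that a change at this site can be large. For compound 3 the expected value is 150 nM, with a range from 40 nM to 800 nM. The expected step, a 1.3-fold lower number from compound 2 to compound 3 (0.12 log units; within the scatter), is estimated to stay within the usual scatter.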

Compound 3, half-maximal inhibitory concentration: 61.2 nM
Compound 3: the middle estimate sits 2.5-fold (0.39 log units) above what was measured, within the range that was stated.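

Swapping methoxymethyl for trifluoromethyl gives a 3.2-fold lower number from compound 2 to compound 3 (0.51 log units; beyond the scatter) in this assay, so this position still responds to change when both groups give a real number, a comparison the earlier pair could not offer. Trifluoromethyl counts no hydrogen-bond donors or acceptors, so neither is needed in this group for inhibition at this level. Set against hydroxy, the change is an at least 160-fold lower number from compound 1 to compound 3 (2.21 log units; beyond the scatter), and that size is only a floor, as the value for compound 1 is a limit: the limit of > 10000 nM in this assay, at which 1 of the 3 values shown sits.

With only hydroxy, methoxymethyl and trifluoromethyl at this position, the compounds shown do not tell whether a chlorine atom, a nitrile or an amine would keep or lose this inhibition. They also leave open whether the same order of groups would hold on a different core.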